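This account rests on a few compounds, and the source may have more. Where it says the series, first, only, none or still open, it means among the compounds named here.

Measured compounds in an assay on cell membranes for binding affinity to 2-oxoglutarate receptor 1 (Rattus norvegicus), read by radioligand binding; on this read-out lower numbers stand for stronger inhibition and higher numbers for weaker inhibition:
compound 1 `CCCCCCCCCNC(=O)[C@H]1OC(n2cnc3c(N)ncnc32)[C@H](O)[C@@H]1O`, 31 nM
compound 2 `CCCCCCCCCCCNC(=O)[C@H]1OC(n2cnc3c(N)ncnc32)[C@H](O)[C@@H]1O`, 123 nM
compound 3 `CCCCCCCCCCCCNC(=O)[C@H]1OC(n2cnc3c(N)ncnc32)[C@H](O)[C@@H]1O`, 163 nM

Compound 1 holds the lowest number of the three; its nearest neighbour is compound 2 at a 4.0-fold higher number from compound 1 to compound 2 (0.60 log units; beyond the scatter), and the furthest is compound 3 at a 5.3-fold higher number from compound 1 to compound 3 (0.72 log units; beyond the scatter), both beyond the scatter. Between compound 2 and compound 3 the step is a 1.3-fold higher number from compound 2 to compound 3 (0.12 log units; within the scatter), within the scatter.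

The new compound 4 `CC(C)CONC(=O)[C@H]1OC(n2cnc3c(N)ncnc32)[C@H](O)[C@@H]1O` differs from compound 1 in one place: isobutoxy in place of nonyl on an amide-type nitrogen. The measured steps all concern lengthening of the chain at a saturated carbon nine or more bonds from the amide-type nitrogen, and each lengthening gave a modestly higher number. None of them concerns what sits directly on the amide-type nitrogen, and none introduces an oxygen there, so they bear on the step to compound 4 only loosely: they show that the size of the group on that nitrogen matters, and that compound 1 carries the best-fitting group among those tested. A much shorter group of a different kind is therefore expected to shift the number in this assay by a step beyond the scatter, most likely upward, with wide uncertainty. Compound 4 is estimated at 200 nM, in the range 25 nM to 1600 nM, which would mean an expected step of a 6.5-fold higher number from compound 1 to compound 4 (0.81 log units; beyond the scatter).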

Compound 4, inhibition constant: 20 nM
Compound 4: middle estimate off by 10-fold (1.00 log units), on the high side; measured number below the stated range.
By their numbers in this assay, from the lowest: compounds 4 and 1 (each within the scatter of the next); then compounds 2 and 3 (each within the scatter of the next).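

In this assay, isobutoxy in place of nonyl on an amide-type nitrogen gives a 1.6-fold lower number from compound 1 to compound 4 (0.19 log units; within the scatter), so at this position a group with fewer heavy atoms, carrying an oxygen and a hydrogen-bond acceptor that nonyl lacks, gives a number within the scatter of that of compound 1. The earlier compounds shown here changed only the far end of a saturated chain, where compound 2 and compound 3 each read higher than compound 1, and they gave no view of a change in the atom attached directly to that nitrogen; compound 4 shows that a long saturated chain is not needed there to keep the number of compound 1. No measurement available here accounts for the close match between the two groups.

Open, on these data alone, is how a plain isobutyl group or an unbranched butoxy group on the amide-type nitrogen would read, which would separate the contribution of the oxygen from that of the branching. Also open, as far as these compounds go, is whether a longer alkoxy chain, a benzyloxy group or a simple methoxy group would stay within the scatter of compound 4.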